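From dimethoxyphenyl to dichlorophenyl in a growth-inhibition series

A few compounds are considered here, and "the series" means these few. Any claim that something is new, unique, unknown or untested is made for them only; others in the source may bear on it.

Measured so far in a functional assay on HOP-62 cells (Homo sapiens) for inhibition, read by sulforhodamine B assay, with a stated time of 48 h; on this read-out higher numbers stand for weaker inhibition of growth and lower numbers for stronger inhibition of growth:
- Compound 1 `O=C(Cc1csc2nc(-c3ccc(Br)cc3)cn12)N/N=C/c1ccccc1`: 15100 nM
- Compound 2 `COc1cccc(OC)c1/C=N/NC(=O)Cc1csc2nc(-c3ccc(Br)cc3)cn12`: 13200 nM

Within the data shown here, compound 2 stands level with compound 1, its only measured neighbour. Compound 3 `O=C(Cc1csc2nc(-c3ccc(Br)cc3)cn12)N/N=C/c1ccc(Cl)cc1Cl` differs from compound 2 at one place: 2,4-dichlorophenyl in place of 2,6-dimethoxyphenyl on a carbon with a double bond to nitrogen. Among the measured compounds shown here, no measured compound carries 2,4-dichlorophenyl, so only one step bears on this change, a 1.1-fold lower number from compound 1 to compound 2 (0.06 log units; within the scatter), where 2,6-dimethoxyphenyl took the place of phenyl on a carbon with a double bond to nitrogen. On that evidence, no step beyond the scatter is expected in this assay, although a single small step is thin support. The expected step is a 1.2-fold lower number from compound 2 to compound 3 (0.08 log units; within the scatter). For compound 3 the estimate is 11000 nM, with an expected range of 4500 nM to 26000 nM.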

Compound 3, concentration for 50% growth inhibition: 16600 nM
Compound 3: the middle estimate sits 1.5-fold (0.18 log units) below what was measured; measured number inside the range.
By their numbers in this assay, from the lowest: compounds 2, 1 and 3 (each within the scatter of the next).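

Placing 2,4-dichlorophenyl on a carbon with a double bond to nitrogen gives a 1.3-fold higher number from compound 2 to compound 3 (0.10 log units; within the scatter), and the same group in place of phenyl gives a 1.1-fold higher number from compound 1 to compound 3 (0.04 log units; within the scatter), both in this assay. Among these compounds, the earlier pair showed only that two methoxy groups left the number level with plain phenyl, whereas compounds 1, 2 and 3 now show that a ring carrying two chlorines also stands level with both, so this change of ring substituents at this place separates none of the three. Nothing available bears on why these numbers stand level.

From the compounds shown here alone, all three compounds keep a phenyl ring at this place, so it remains open whether an amine, a carboxylic acid or a saturated cyclohexyl ring there would move the number beyond the scatter. Going by these compounds, whether the same level holds in other cell lines also remains open.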